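Trading a basic side chain for a plain hexyl chain

This account rests on a few compounds, and the source may have more. Where it says the series, first, only, none or still open, it means among the compounds named here.

Two compounds have been measured in an assay on membranes from liver for displacement of a labelled ligand from Sigma intracellular receptor 2 (Rattus norvegicus), read by scintillation counting, with a stated time of 120 min; a higher number here means a weaker inhibitor, a lower number a stronger inhibitor:

Compound 1, `Cc1cccc2sc(NC(=O)CCN3CCN(C(C)(C)C)CC3)nc12`: 200 nM
Compound 2, `Cc1cccc2sc(NC(=O)CCN3CCN(CCN(C)C)CC3)nc12`: > 1000 nM

Compound 2 gives only a limit of the assay and not a number, sitting at the limit of > 1000 nM in this assay, at which 1 of the 2 values shown sits. The two compounds share one core and differ only in the group on the amine nitrogen in the ring; putting 2-(dimethylamino)ethyl in place of tert-butyl there brought an at least 5.0-fold higher number from compound 1 to compound 2 (0.69 log units; beyond the scatter).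

Compound 3, `CCCCCCN1CCN(CCC(=O)Nc2nc3c(C)cccc3s2)CC1`, is the next compound in line. Its difference from compound 2 is butyl in place of dimethylamino on a saturated chain carbon, two bonds along the chain from an amine nitrogen in a ring; read from the ring nitrogen outward, the 2-(dimethylamino)ethyl arm becomes a hexyl arm. Going by the values given here, the one measured step bears on this directly, since that step an at least 5.0-fold higher number from compound 1 to compound 2 (0.69 log units; beyond the scatter) arrived together with the dimethylamino group that compound 3 now loses. Removing it is expected to bring the number back down, toward where the tert-butyl compound stands, though how far is uncertain. For compound 3 this means an expected step of an at least 6.6-fold lower number from compound 2 to compound 3 (0.82 log units; beyond the scatter). Compound 3 is therefore estimated to give 150 nM in this assay, with a likely range from 30 nM to 800 nM.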

Compound 3, inhibition constant: 158 nM
Beside the measured number, compound 3's estimate is 1.1-fold (0.02 log units) below it; measured number inside the range.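

Butyl in place of dimethylamino on a saturated chain carbon, two bonds along the chain from an amine nitrogen in a ring, gave an at least 6.3-fold lower number from compound 2 to compound 3 (0.80 log units; beyond the scatter), so in this assay a long arm on that ring nitrogen is compatible with binding, and the loss seen with compound 2 goes with the dimethylamino group rather than with the arm's length. Hexyl in place of tert-butyl gave a 1.3-fold lower number from compound 1 to compound 3 (0.10 log units; within the scatter), which means that a straight chain and this compact branched group cannot be told apart here. The step from compound 2 is only a minimum, because that compound's reading is a limit and not a number: the limit of > 1000 nM in this assay, at which 1 of the 3 values shown sits.

Still open, going by these compounds, is whether dimethylamino is a special case, since a hydroxyl or methoxy group in its place would show whether other heteroatom groups in that spot go with a similar loss. Also open, on these data alone, is how far the chain can change, as a butyl or octyl chain on the ring nitrogen would show whether the number moves with chain length at all.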